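Adding Chloro to the Pyridin-3-yl Arm of Compound 3

A few compounds are considered here, and "the series" means these few. Any claim that something is new, unique, unknown or untested is made for them only; others in the source may bear on it.

Of the compounds shown here, three sharing one core have been measured in a functional assay on A549 cells (Homo sapiens) for antiproliferative activity, read by MTT assay, with a stated time of 48 h; a lower number here means a stronger inhibitor, a higher number a weaker inhibitor. Compound 1 `Clc1cccc(Nc2ncnc3ccc(NCc4c[nH]c5ccccc45)cc23)c1` gives 2330 nM in this assay. Within the data shown here, compound 2 `CSCCCNc1ccc2ncnc(Nc3cccc(Cl)c3)c2c1` gives 3820 nM, and the single measured step, a 1.6-fold higher number from compound 1 to compound 2 (0.21 log units; within the scatter), shows how little that swap changed the result. Compound 3 `O=C(/C=C/c1cccnc1)Nc1ccc2ncnc(Nc3cccc(Cl)c3)c2c1` gives 4320 nM; its number sits close to those of compounds 1 and 2, with both gaps inside the usual scatter, so the three cannot be told apart by these readings.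

Compound 4 `O=C(/C=C/c1cccnc1Cl)Nc1ccc2ncnc(Nc3cccc(Cl)c3)c2c1` differs from compound 3 by chloro in place of hydrogen on an aromatic carbon. Among the measured compounds shown here, no measured step bears on this kind of change: the only step available exchanges a group on a saturated chain carbon, not on the pyridin-3-yl arm, and even that step stayed within the scatter. These numbers therefore give no ground for a move in either direction. Compound 4 is expected to shift little, as a 1.1-fold lower number from compound 3 to compound 4 (0.03 log units; within the scatter). The estimate for compound 4 in this assay is 4000 nM, with a range from 1500 nM to 11000 nM.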

Compound 4, half-maximal inhibitory concentration: 2920 nM
Estimate against measurement, compound 4: 1.4-fold (0.14 log units) above; the range from low to high includes it.
By their numbers in this assay, from the lowest: compounds 1, 4, 2 and 3 (each within the scatter of the next).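

In this assay, placing chloro on the aromatic carbon next to the ring nitrogen and ortho to a large group gives a 1.5-fold lower number from compound 3 to compound 4 (0.17 log units; within the scatter). Among these compounds, this is the first measured step on the pyridin-3-yl arm, and since it stays within the scatter, it shows neither a gain nor a loss from adding this one heavy atom at this place. Nothing measured alongside these readings offers an explanation for the size of this step.

From the compounds shown here alone, it remains open whether a different group at this same place, such as methoxy, an amine or a carboxylic acid, would move the number beyond the scatter. Going by these compounds, it is equally open whether chloro on another carbon of the pyridin-3-yl arm would read any differently.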